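From 3-Bromophenyl to 4-Hydroxyphenyl on the Amide Nitrogen

The compounds below may be only part of what the source reports. "The series", "measured", "known", "first", "only" and "open" are said of these compounds alone.

In a functional assay on A549 cells (Homo sapiens) for inhibition, read by CCK-8 assay, with a stated time of 72 h, tested at 10 uM (a higher number here means more inhibition of growth at the concentration tested, a lower number less inhibition of growth), compound 1 `COc1ccc(NC(=O)C2(C(=O)Nc3ccc(Nc4ncc5cc(C(=O)N(C)C)n(C6CCCC6)c5n4)cc3)CC2)cc1` gives 78.5%, while compound 2 `CN(C)C(=O)c1cc2cnc(Nc3ccc(NC(=O)C4(C(=O)Nc5cccc(Br)c5)CC4)cc3)nc2n1C1CCCC1` gives 92.2%, the higher of the two numbers. Compound 3 `CN(C)C(=O)c1cc2cnc(Nc3ccc(NC(=O)C4(C(=O)Nc5ccc(O)cc5)CC4)cc3)nc2n1C1CCCC1` remains unmeasured and differs from compound 2 by 4-hydroxyphenyl in place of 3-bromophenyl on an amide-type nitrogen. Going by the values given here, one measured step bears on this change: a number 13.7 percentage points higher from compound 1 to compound 2 (beyond the scatter), which introduced 3-bromophenyl at the same place. Compound 3 gives up that group again, so a fall of similar, modest size is expected in this assay. The expected change is a number 16.2 percentage points lower from compound 2 to compound 3 (beyond the scatter). Compound 3 is estimated at 76%, with an expected range of 58% to 90%.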

Compound 3, percent growth inhibition at one concentration: 94.4%
The estimate for compound 3 lay 18.4 percentage points below the measured number; the whole stated range lies below it.
By their numbers in this assay, from the lowest: compound 1; then compounds 2 and 3 (each within the scatter of the next).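

Going by these compounds alone, the change to 4-hydroxyphenyl brought a number 2.2 percentage points higher from compound 2 to compound 3 (within the scatter) in this assay, so 3-bromophenyl is not the only group on this amide-type nitrogen that gives such a number. Taking the methyl off the oxygen on the aromatic ring gave a number 15.9 percentage points higher from compound 1 to compound 3 (beyond the scatter), so that one methyl separates the lower number from the higher one. Nothing available explains either step. Open, on these data alone, is whether an amine or a carboxylic acid in place of the hydroxyl would keep the number. Also open, as far as these compounds go, is whether compound 2 and compound 3 would separate at a lower concentration.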